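Methyl on the Amide Nitrogen: an Expected Shift

The source may report more compounds than this note shows. Statements on the series, on what has been measured and on what is new or still open speak of the compounds shown alone.

In a functional assay on HEK293 cells for agonist activity at G-protein coupled receptor 39 (Mus musculus), read by inositol phosphate accumulation (on this read-out lower numbers stand for an effect already at smaller amounts and higher numbers for an effect only at larger amounts of compound), compound 1 `CNc1nc(NCc2ccc(NC(C)=O)cc2)cc(-c2ccccn2)n1` gives 2 nM, the lower of the two numbers recorded so far. Compound 2 `FC(F)(F)Oc1ccc(CNc2nc(NCC3CC3)cc(-c3ccccn3)n2)cc1` gives 22 nM in this assay, a higher number that lies beyond the usual scatter of the method, so compound 1 stands as the more potent of the pair. Compound 3 `CNc1nc(NCc2ccc(N(C)C(C)=O)cc2)cc(-c2ccccn2)n1` has not yet been tested. It differs from compound 1 by methyl in place of hydrogen on an amide-type nitrogen; the acetamido group of compound 1 thereby becomes an acetyl(methyl)amino group. Among the measured compounds shown here, no measured pair in this set carries such a change, so its effect can only be estimated. The author expects the step of a 3.0-fold higher number from compound 1 to compound 3 (0.48 log units; beyond the scatter) to be a modest one toward a higher number, of a size that may just reach beyond the scatter. Compound 3 is therefore estimated at 6 nM, with a range from 1.5 nM to 30 nM.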

Compound 3, half-maximal effective concentration: 2610 nM
The estimate for compound 3 lay 440-fold (2.64 log units) below the measured number, and the stated range ends below it.
By their numbers in this assay, from the lowest: compound 1; then compound 2; then compound 3.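

In this assay, among the compounds shown here, methyl in place of hydrogen on the amide-type nitrogen gives a 1300-fold higher number from compound 1 to compound 3 (3.12 log units; beyond the scatter), the first step in this set that isolates this position. A single added carbon on this nitrogen, with the rest of compound 1 unchanged, is thus enough to move the number by a large margin, so the response at this receptor depends strongly on what this nitrogen carries. Nothing at hand tells why the step is so large.

The compounds shown leave open whether a longer chain such as ethyl on this nitrogen would give a similar shift or a different one. They also leave open whether, with the amide hydrogen kept, the acetyl part could give way to a methanesulfonyl group or a urea.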